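The source may hold more compounds than are shown below. What is called first, only, known or untested is meant among the compounds shown, and "the series" means these compounds.

Measured compounds in an assay for inhibition of Thromboxane-A synthase (Homo sapiens); a lower number here means a stronger inhibitor, a higher number a weaker inhibitor:
- Compound 1, `O=C(O)c1ccc2oc(Cn3ccnc3)cc2c1`: 12 nM
- Compound 2, `Cc1c(Cn2ccnc2)sc2ccc(C(=O)O)cc12`: 17 nM
- Compound 3, `Cc1c(Cn2ccnc2)sc2cc(C(=O)O)ccc12`: 18 nM

Compound 2 holds the second highest of the three numbers. Its nearest neighbour is compound 3 and its furthest is compound 1, yet both gaps lie within the usual scatter of this assay, so the three compounds cannot be told apart on these numbers; none of them can be called the stronger or the weaker inhibitor.

The next compound, compound 4, `O=C(O)c1ccc2sc(Cn3ccnc3)cc2c1`, differs from compound 2 in one place: hydrogen in place of methyl on an aromatic carbon. For the measured compounds named here, no measured pair shows this exact change, so there is no step to lean on. Compound 1 also carries no methyl at this place and gives 12 nM, a number within the scatter of compound 2. The step from compound 2 to compound 4 is therefore expected to be small, in either direction, or none beyond the scatter: a 1.1-fold lower number from compound 2 to compound 4 (0.05 log units; within the scatter). Compound 4 is estimated at 15 nM, with a likely range from 6 nM to 40 nM.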

Compound 4, half-maximal inhibitory concentration: 15 nM
Compound 4: middle estimate and measured number agree at the digits printed; the range from low to high includes it.
By their numbers in this assay, from the lowest: compounds 1, 4, 2 and 3 (each within the scatter of the next).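

In this assay, for the compounds shown here, hydrogen in place of methyl on this aromatic carbon, next to the ring atom that bears the (1H-imidazol-1-yl)methyl group, gives a 1.1-fold lower number from compound 2 to compound 4 (0.05 log units; within the scatter) and so provides the first direct reading of this change. In this one pair, the methyl can go without a difference that this measurement can detect, so the inhibition seen in compound 2 does not depend on that methyl. Nothing measured here explains this result.

The compounds shown leave open whether a larger group at this position, such as an ethyl group, a longer chain or an amine, would also leave the number within the scatter. From the compounds shown here alone, it also remains open whether hydrogen in place of methyl would do as little on the core of compound 3.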